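The compounds below may be only part of what the source reports. "The series", "measured", "known", "first", "only" and "open" are said of these compounds alone.

Measured so far:
- compound 1 `Cc1cc(C)cc(SCc2ccc(/C=C/C(=O)Nc3ccccc3N)cc2)c1`: 7.98%
- compound 2 `Nc1ccccc1NC(=O)/C=C/c1ccc(CSc2ccc(C(F)(F)F)cn2)cc1`: 4.42%
- compound 3 `Cc1ccc(SCc2ccc(/C=C/C(=O)Nc3ccccc3N)cc2)cc1`: 6.23%

In a functional assay on HCT-116 cells (Homo sapiens) for inhibition, read by CCK-8 assay, with a stated time of 72 h, tested at 2 uM (on this read-out lower numbers stand for less inhibition of growth and higher numbers for more inhibition of growth at the one concentration tested), compound 3 gives 6.23%, the middle of the three numbers, and all three lie within the scatter of each other. Compound 4 `CC(C)(C)c1ccc(SCc2ccc(/C=C/C(=O)Nc3ccccc3N)cc2)cc1` carries tert-butyl in place of methyl on an aromatic carbon, para to a large group: tert-butyl in place of methyl on an aromatic carbon. For the measured compounds named here, the steps that bear on this change are those at the group on sulfur, a number 1.8 percentage points lower from compound 1 to compound 3 (within the scatter) and a number 1.8 percentage points higher from compound 2 to compound 3 (within the scatter), both within the scatter. Neither involves a tert-butyl, so they are only a loose guide. No step beyond the scatter is expected. The estimate is a number 0.8 percentage points higher from compound 3 to compound 4 (within the scatter), which is expected to stay within the scatter. Compound 4 is expected at 7%, with an estimated range of 2% to 15%.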

Compound 4, percent growth inhibition at one concentration: 6.66%
Compound 4: middle estimate off by 0.3 percentage points, on the high side, and the stated range covers the measured number.
By their numbers in this assay, from the lowest: compounds 2, 3, 4 and 1 (each within the scatter of the next).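

In this assay the position para to a large group tolerates tert-butyl in place of methyl, four heavy atoms for one, with a number 0.4 percentage points higher from compound 3 to compound 4 (within the scatter) and no separation from the smaller group. The 4-(tert-butyl)phenyl group on sulfur also stays level with the other groups there, with a number 2.2 percentage points higher from compound 2 to compound 4 (within the scatter) and a number 1.3 percentage points lower from compound 1 to compound 4 (within the scatter). No evidence on hand accounts for these numbers.

Going by these compounds, whether an amine, a carboxylic acid or a longer chain at this position would move the number beyond the scatter stays open. On these data alone, whether these four compounds would separate at another concentration also stays open.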